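A few compounds are considered here, and "the series" means these few. Any claim that something is new, unique, unknown or untested is made for them only; others in the source may bear on it.

In a functional assay on Ramos cells (Homo sapiens) for antiproliferative activity, read by CCK-8 assay, with a stated time of 72 h, tested at 40 uM (a higher number here means more inhibition at the concentration tested (going by the name of the read-out), a lower number less inhibition), compound 3 `CN1CCN(c2ccc(Nc3nc(-c4cccc(NC(=O)c5ccc(Cl)cc5)c4)sc3C(N)=O)cc2)CC1` gives 99%, the highest of the three numbers measured. Compound 2 `CN1CCN(c2ccc(Nc3nc(-c4cccc(NC(=O)c5ccccc5F)c4)sc3C(N)=O)cc2)CC1` gives 95.5% in this assay, and compound 1 `CCOC(=O)c1sc(-c2cccc(NC(=O)c3ccco3)c2)nc1Nc1ccc(N2CCN(C)CC2)cc1` gives 50.2%. Going by the values given here, the one measured step between neighbours that differ in a single place is a number 3.5 percentage points higher from compound 2 to compound 3 (within the scatter), so exchanging one aryl group for another on the carbonyl carbon left the number where it was.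

Compound 4 `CN1CCN(c2ccc(Nc3nc(-c4cccc(NC(=O)c5ccco5)c4)sc3C(N)=O)cc2)CC1` differs from compound 3 in one place: furan-2-yl in place of 4-chlorophenyl on a carbonyl carbon. Among the compounds with values here, no measured step matches this change exactly. Compound 1 carries the same furan-2-yl group on its carbonyl carbon but also an ester where compound 4 carries a primary amide, so its lower number cannot be assigned to the furan alone. The step of a number 3.5 percentage points higher from compound 2 to compound 3 (within the scatter) suggests that an aryl exchange at this position may not move the number beyond the scatter, while the value of compound 1 leaves room for a drop. Compound 4 is therefore expected to give 82% in this assay, between 50% and 99%, a step of a number 17 percentage points lower from compound 3 to compound 4 (beyond the scatter).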

Compound 4, a percentage reported as inhibition, at one concentration (the size of the read-out at that concentration, not a potency): 96.7%
Compound 4: middle estimate off by 14.7 percentage points, on the low side, and the stated range covers the measured number.
By their numbers in this assay, from the lowest: compound 1; then compounds 2, 4 and 3 (each within the scatter of the next).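

With the primary amide kept, the furan-2-yl group on the carbonyl carbon does not set compound 4 apart from the two compounds carrying a substituted phenyl there in this assay (a number 2.3 percentage points lower from compound 3 to compound 4 (within the scatter); a number 1.2 percentage points higher from compound 2 to compound 4 (within the scatter)). With furan-2-yl held fixed, amino in place of ethoxy on the carbonyl carbon gives the large step (a number 46.5 percentage points higher from compound 1 to compound 4 (beyond the scatter)), so the low number of compound 1 goes with its ester and not with the furan. No measurement here explains either result.

As far as these compounds go, all three amides carry an aromatic ring on this carbonyl carbon, so it remains open whether a cyclohexyl or methyl group there would keep the number. Also open, from the compounds shown here alone, is how a carboxylic acid or a methylamide would fare in place of the primary amide.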